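The source may report more compounds than this note shows. Statements on the series, on what has been measured and on what is new or still open speak of the compounds shown alone.

Working notes on the series. In a functional assay on A549 cells (Homo sapiens) for cytotoxicity, read by MTT assay, with a stated time of 48 h (on this read-out lower numbers stand for stronger inhibition and higher numbers for weaker inhibition), compound 1 (`COc1cc([C@@H]2C[C@@]2(CO)C(=O)Nc2ccccc2)cc(OC)c1OC`) gives 43200 nM and compound 3 (`COc1cc([C@H]2C[C@]2(CO)C(=O)NCc2ccc(C)cc2)cc(OC)c1OC`) gives 60700 nM and these two values lie within the scatter of each other. Compound 2 (`CCOC(=O)[C@@]1(C(=O)NCc2ccc(C)cc2)C[C@H]1c1cc(OC)c(OC)c(OC)c1`) gives 17100 nM and so sits beyond the scatter on the lower side of compound 3. Compound 3 therefore shares the high-number end of this small set with compound 1.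

The next compound is compound 4 (`COc1cc([C@@H]2C[C@@]2(CO)C(=O)NCc2ccc(C)cc2)cc(OC)c1OC`), and the change is the two compounds have the same atoms and bonds and differ only in configuration as drawn: 2 of 2 stereo elements differ (all stereocentres are inverted: mirror images); a stereocentre at a saturated ring carbon is drawn R in compound 3 and S in compound 4; a stereocentre at a saturated ring carbon is drawn S in compound 3 and R in compound 4. The two compounds have the same atoms and bonds, and all stereocentres are inverted, which makes them mirror images.

For the measured compounds named here, no measured pair isolates configuration, so any expectation here has no direct precedent. With the configuration drawn as in compound 4 but a different amide group, compound 1 gives 43200 nM and that value stays within the scatter of compound 3. On that slim basis, the expected size of a 1.3-fold lower number from compound 3 to compound 4 (0.10 log units; within the scatter) is none beyond the scatter in this assay and a slight move toward a lower number is the most that is expected. Compound 4 is estimated at 48000 nM (expected range 20000 nM to 110000 nM).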

Compound 4, half-maximal inhibitory concentration: 46300 nM
Compound 4: middle estimate off by 1.0-fold (0.02 log units), on the high side; low and high end bracket the measured number.
By their numbers in this assay, from the lowest: compound 2; then compounds 1, 4 and 3 (each within the scatter of the next).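

In this assay, configuration can now be read directly, and a 1.3-fold lower number from compound 3 to compound 4 (0.12 log units; within the scatter) shows that inverting both stereocentres leaves the number within the scatter, a reading that concerns configuration alone because of one fact: the fact that compounds 3 and 4 differ only in the configuration as drawn

With the configuration as drawn in compound 4, 4-methylbenzyl in place of phenyl on the amide-type nitrogen gives a 1.1-fold higher number from compound 1 to compound 4 (0.03 log units; within the scatter), so this exchange also stays within the scatter. Hydroxymethyl in place of ethoxycarbonyl on the saturated ring carbon gives a 2.7-fold higher number from compound 2 to compound 4 (0.43 log units; beyond the scatter), the only one of these three steps beyond the scatter, which makes that ring-carbon substituent the one place here where a change registers, though modestly.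

Still open is whether configuration stays equally silent with ethoxycarbonyl on that ring carbon, since the mirror-image comparison shown covers hydroxymethyl only. Also open, from the compounds shown here alone, is whether a carboxylic acid or an aminomethyl group on that ring carbon would read like hydroxymethyl or like ethoxycarbonyl, and whether a longer chain on the amide-type nitrogen would remain within the scatter of 4-methylbenzyl and phenyl.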